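The compounds below may be only part of what the source reports. "The series", "measured", "known", "first", "only" and "open" are said of these compounds alone.

Measured in a functional assay on NCI-H1299 cells (Homo sapiens) for cytotoxicity, read by resazurin assay, with a stated time of 72 h; on this read-out higher numbers stand for weaker inhibition and lower numbers for stronger inhibition:
Compound 1 `COc1cc(/C=C/C(=O)OCCCO[N+](=O)[O-])ccc1OCCCO[N+](=O)[O-]`: > 50000 nM, a limit
Compound 2 `COc1cc(/C=C/C(=O)OCCCO[N+](=O)[O-])ccc1O`: 28300 nM
Compound 3 `COc1cc(/C=C/C(=O)OCCCCCO[N+](=O)[O-])ccc1OCCCCCO[N+](=O)[O-]`: > 50000 nM, a limit

Compound 1 stands at the limit of > 50000 nM in this assay, at which 2 of the 3 values shown sit, so its place in this assay is known only as a limit, and compound 3 shares that limit. Compound 4 `O=C(/C=C/c1ccc(OCCCO[N+](=O)[O-])c(O)c1)OCCCO[N+](=O)[O-]` differs from compound 1 in one place: hydrogen in place of methyl on an oxygen on an aromatic ring. In words, this is hydrogen in place of methyl on an oxygen on an aromatic ring, or methoxy to hydroxy.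

Within the data shown here, no measured step makes exactly this change. The nearest is an at least 1.7-fold lower number from compound 1 to compound 2 (0.24 log units; that floor lies within the scatter). That step also leaves a hydroxy on an aromatic ring, but there hydrogen takes the place of 3-(nitrooxy)propyl, and a different oxygen is involved. Among the measured compounds shown here, with compound 2 at 28300 nM as the only true number, the evidence is thin. A small move toward lower numbers in this assay is expected from compound 1 to compound 4, and it may not clear the usual scatter, so compound 4 could also end at the same limit. The expected change is an at least 1.4-fold lower number from compound 1 to compound 4 (0.15 log units; that floor lies within the scatter). For compound 4 the estimated value is 35000 nM, with an expected range from 13000 nM to 60000 nM.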

Compound 4, half-maximal inhibitory concentration: > 50000 nM
Compound 4: only a limit was reported; the forecaster's own chance of this, stated with the estimate: 45%; at least 1.4-fold (0.15 log units) between middle value and limit.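

In this assay compound 4 gives > 50000 nM, which is a limit. Compound 1 also stands at a limit, so no step can be read from compound 1 to compound 4: the limit of > 50000 nM in this assay, at which 3 of the 4 values shown sit. The compounds shown leave open whether hydrogen in place of methyl on an oxygen on an aromatic ring changes the read-out at all.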